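Series notes: bromophenoxymethyl triazole on the shared coumarin-like core

This account rests on a few compounds, and the source may have more. Where it says the series, first, only, none or still open, it means among the compounds named here.

For the measured compounds named here, compound 2 `O=c1cc(-n2cc(COc3cccnc3)nn2)c2cc(Br)ccc2o1` gives 39800 nM in a functional assay on MCF7 cells (Homo sapiens) for antiproliferative activity, read by MTT assay, with a stated time of 48 h; a higher number here means a weaker inhibitor, a lower number a stronger inhibitor; this is the highest of the two numbers so far, with compound 1 `O=c1cc(-n2cc(-c3ccccc3)nn2)c2cc(Br)ccc2o1` at 9450 nM the nearest. Going by the values given here, the one measured step, a 4.2-fold higher number from compound 1 to compound 2 (0.62 log units; beyond the scatter), concerns a different change from the one considered here, so it bears on compound 3 only as a rough guide. Compound 3 `O=c1cc(-n2cc(COc3ccc(Br)cc3)nn2)c2cc(Br)ccc2o1` is not yet measured; it differs from compound 2 by 4-bromophenyl in place of pyridin-3-yl on an oxygen on a saturated carbon. Among the compounds with values here, no measured pair isolates this swap of ring partner on the oxygen. Compound 1, which carries a carbon-only aromatic ring directly on the triazole, gives 9450 nM, and compound 3 also carries a carbon-only ring, though through the oxymethyl link; the expected step is therefore toward a lower number but of moderate size, a 1.8-fold lower number from compound 2 to compound 3 (0.26 log units; within the scatter). The estimate for compound 3 in this assay is 22000 nM, within the range 7000 nM to 70000 nM.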

Compound 3, half-maximal inhibitory concentration: 1920 nM
For compound 3 the middle estimate is 11-fold (1.06 log units) above the measured one; the whole stated range lies above it.
By their numbers in this assay, from the lowest: compound 3; then compound 1; then compound 2.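

In this assay, 4-bromophenyl in place of pyridin-3-yl on an oxygen on a saturated carbon gives a 21-fold lower number from compound 2 to compound 3 (1.32 log units; beyond the scatter), so the ring partner on this oxygen can shift the number well beyond the scatter. The earlier pair left open whether a compound with the oxymethyl link could fall under the directly attached phenyl; compound 1 gives 9450 nM and compound 3 gives 1920 nM, which puts compound 3 on the lower side, so the link alone does not fix a high number. No measurement on hand accounts for the size of this step.

The swap removes the ring nitrogen and adds bromine together, and the compounds shown do not separate these two changes. Going by these compounds, how 4-chlorophenyl or 4-methoxyphenyl on the same oxygen would compare remains open.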